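From compound 3 to compound 4: a 4-ethylphenyl swap

The source may hold more compounds than are shown below. What is called first, only, known or untested is meant among the compounds shown, and "the series" means these compounds.

Of the compounds shown here, three on the shared core have been read so far: compound 1 `Nc1ccc(-c2ccc3ncc(-c4noc(C(F)(F)F)n4)cc3c2)cn1`, compound 2 `FC(F)(F)c1nc(-c2cnc3ccc(-c4ccccc4)cc3c2)no1` and compound 3 `Cc1nc(-c2cnc3ccc(-c4ccc(N)nc4)cc3c2)no1`. In a functional assay on RD cells (Homo sapiens) for inhibition, read by luminescence and ATP content, with a stated time of 72 h (a lower number here means that less compound is tolerated, a higher number that more compound is tolerated), compound 1 gives > 2500 nM, which is a limit. Compound 2 gives > 22200 nM, also a limit. Compound 3 gives > 7400 nM, again a limit, so its standing is known only as a limit and not as a number.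

Compound 4 `CCc1ccc(-c2ccc3ncc(-c4noc(C)n4)cc3c2)cc1` carries 4-ethylphenyl in place of 6-aminopyridin-3-yl on an aromatic carbon. Among the measured compounds shown here, two measured steps bear on this change. The closer one, a step that the two limits leave unreadable from compound 1 to compound 2, puts phenyl in place of 6-aminopyridin-3-yl, and its size cannot be read. The other, a step that the two limits leave unreadable from compound 1 to compound 3, puts methyl in place of trifluoromethyl, and its size cannot be read either. For the measured compounds named here, no measured compound carries the ethyl group on the phenyl ring.

Neither step therefore supplies a size or a direction for this assay, and no shift beyond the scatter is assumed. The expected change is a step that the limit leaves unreadable from compound 3 to compound 4, an estimate with no firm direction. For compound 4 the estimated value is 10000 nM, with an expected range from 2500 nM to 30000 nM.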

Compound 4, half-maximal cytotoxic concentration: > 7400 nM
Compound 4: only a limit was reported (the forecaster's own chance of this, stated with the estimate: 60%); the middle value does not contradict the limit.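

In this assay compound 4 gives > 7400 nM, a limit. Compound 3 gives > 7400 nM, also a limit. No step can be read between compound 3 and compound 4. The compounds shown leave open where the half-maximal cytotoxic concentration of any of them lies as a number, and whether 4-ethylphenyl in place of 6-aminopyridin-3-yl changes it.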